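Ring nitrogen swap on the base of compound 1

The source may report more compounds than this note shows. Statements on the series, on what has been measured and on what is new or still open speak of the compounds shown alone.

Compound 1 `Nc1ccn(C[C@H](O)[C@H]2OC(=O)C(OCc3ccccc3)=C2OCc2ccccc2)c(=O)n1` is measured in a functional assay on MIA PaCa-2 cells (Homo sapiens) for inhibition, read by MTT assay, with a stated time of 72 h; a lower number here means a stronger inhibitor, a higher number a weaker inhibitor. In this assay compound 1 returns only a limit, > 100000 nM. Compound 2 `O=C1O[C@H]([C@@H](O)Cn2ccc(NC(=O)c3ccccc3)nc2=O)C(OCc2ccccc2)=C1OCc1ccccc1`, carrying a benzoyl in place of hydrogen on a nitrogen on an aromatic ring, likewise returns only a limit in this assay, > 100000 nM. The step that the two limits leave unreadable from compound 1 to compound 2 therefore cannot be read. Compound 3 `Nc1ccn(CCC2(N)OC(=O)C(OCc3ccccc3)=C2OCc2ccccc2)c(=O)n1` also returns only a limit in this assay, > 100000 nM. For the measured compounds named here, all three values sit at the limit of > 100000 nM in this assay, at which 3 of the 3 values shown sit, so no measured step has a readable size.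

Compound 4 `Nc1ncn(C[C@H](O)[C@H]2OC(=O)C(OCc3ccccc3)=C2OCc2ccccc2)c(=O)n1` differs from compound 1 by a group of 8 heavy atoms (3 carbon, 4 nitrogen, 1 oxygen; one six-membered aromatic ring with 3 hetero atoms) in place of a group of 8 heavy atoms (4 carbon, 3 nitrogen, 1 oxygen; one six-membered aromatic ring with 2 hetero atoms), on a saturated chain carbon, two bonds along the chain from an oxygen on a saturated carbon and a saturated ring carbon. Going by the values given here, no measured step touches this change; the only step available, from compound 1 to compound 2, is unreadable, and every value sits at the limit. With nothing measured to pull against the limit, compound 4 is expected to stay there too, the estimated step that the limit leaves unreadable from compound 1 to compound 4 being no more than the scatter. Compound 4 is thus estimated at 150000 nM, with a range from 30000 nM to 600000 nM, most likely reported only as a limit.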

Compound 4, half-maximal inhibitory concentration: 71700 nM
The estimate for compound 4 lay 2.1-fold (0.32 log units) above the measured number; low and high end bracket the measured number.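

Among the compounds shown, only compound 4 gives a number, 71700 nM in this assay, so the ring with 3 hetero atoms on the saturated chain carbon is the one change here that yields a readable value. The other three compounds remain at a limit of the assay, and the steps among them cannot be read: the limit of > 100000 nM in this assay, at which 3 of the 4 values shown sit. The swap gives an at least 1.3-fold lower number from compound 1 to compound 4 (0.14 log units; that floor lies within the scatter), so the change is not shown to exceed the scatter, although its true size may be larger.

As far as these compounds go, how far compound 1 actually lies from compound 4 remains open, since only a floor is available. Also open, from the compounds shown here alone, is whether benzoyl on the ring nitrogen of compound 4, or a carboxylic acid or longer chain at the saturated chain carbon, would give a lower number.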